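Sulfonamide aryl swap: chloro to methyl on compound 3

The source may hold more compounds than are shown below. What is called first, only, known or untested is meant among the compounds shown, and "the series" means these compounds.

Three compounds share one core and differ at the nitrogen on the aromatic ring. Compound 1 `O=C(/C=C/c1cccc(NC(=O)c2ccccc2Cl)c1)c1nc2ccccc2[nH]1` gives 1280 nM in a functional assay on HCT-116 cells (Homo sapiens) for antiproliferative activity, read by MTT assay, with a stated time of 48 h; on this read-out higher numbers stand for weaker inhibition and lower numbers for stronger inhibition. Compound 2 `Cc1ccccc1C(=O)Nc1cccc(/C=C/C(=O)c2nc3ccccc3[nH]2)c1` gives 1870 nM in this assay, and the step of a 1.5-fold higher number from compound 1 to compound 2 (0.16 log units; within the scatter) is the only measured case of methyl in place of chloro in this set. Compound 3 `O=C(/C=C/c1cccc(NS(=O)(=O)c2cccc(Cl)c2)c1)c1nc2ccccc2[nH]1` gives 737 nM in this assay, the lowest of the three numbers; against compound 1 the step of a 1.7-fold lower number from compound 1 to compound 3 (0.24 log units; within the scatter) stays within the scatter, while against compound 2 the step of a 2.5-fold lower number from compound 2 to compound 3 (0.40 log units; beyond the scatter) reaches beyond it.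

Compound 4 `Cc1ccc(S(=O)(=O)Nc2cccc(/C=C/C(=O)c3nc4ccccc4[nH]3)c2)cc1` carries 4-methylphenyl in place of 3-chlorophenyl on a sulfonyl sulfur. Going by the values given here, no measured step changes the aryl group on a sulfonyl sulfur; the nearest analogy, a 1.5-fold higher number from compound 1 to compound 2 (0.16 log units; within the scatter), sits on an amide carbonyl and stayed within the scatter. The change from compound 3 to compound 4 is therefore expected to be small, if anything a slightly higher number, as the step of a 1.3-fold higher number from compound 3 to compound 4 (0.11 log units; within the scatter) means. Compound 4 is estimated at 950 nM in this assay, between 400 nM and 2300 nM.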

Compound 4, half-maximal inhibitory concentration: 1990 nM
The estimate for compound 4 lay 2.1-fold (0.32 log units) below the measured number; the measured number falls inside the stated range.
By their numbers in this assay, from the lowest: compounds 3, 1, 2 and 4 (each within the scatter of the next, the first and the last beyond it).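

Going by these compounds alone, on a sulfonyl sulfur the aryl group does move the number in this assay: 4-methylphenyl in place of 3-chlorophenyl gives a 2.7-fold higher number from compound 3 to compound 4 (0.43 log units; beyond the scatter) as the first measured change at this place, beyond the scatter, whereas methyl in place of chloro on the amide side gave a 1.5-fold higher number from compound 1 to compound 2 (0.16 log units; within the scatter) within it. The sulfonyl linkage alone does not set the number, since a 1.1-fold higher number from compound 2 to compound 4 (0.03 log units; within the scatter) and a 1.6-fold higher number from compound 1 to compound 4 (0.19 log units; within the scatter) both stay within the scatter, leaving compound 4 level with the two amides. No measurement here accounts for the step from 3-chlorophenyl to 4-methylphenyl.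

The step changes the substituent and its ring position at once, and these compounds do not separate the two. From the compounds shown here alone, how an unsubstituted phenyl, or an aryl carrying an amine or a carboxylic acid, would read on the sulfonyl sulfur stays open.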